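Series notes: replacing the iodoacetamidomethyl arm at the five-position

This account rests on a few compounds, and the source may have more. Where it says the series, first, only, none or still open, it means among the compounds named here.

Working notes on three measured compounds and one still to be measured, all assessed in an ADME assay on L1210/0 cells (Mus musculus) for cytotoxicity, with a stated time of 48 h; a higher number here means a weaker inhibitor, a lower number a stronger inhibitor. Compound 1 `O=C1OC(C(O)Cn2cc(F)c(=O)[nH]c2=O)C(OCc2ccccc2)=C1OCc1ccccc1` gives 140000 nM. Compound 2 `O=C(CI)NCc1cn([C@H]2C[C@H](O)[C@@H](CO)O2)c(=O)[nH]c1=O` gives 107000 nM. These two numbers sit within the usual scatter of each other, so no order between compound 1 and compound 2 is claimed. Compound 3 `CC(C)Nc1ncnc2c1ncn2C1C[C@@H](CO)[C@@H](CO)C1` returns only a limit of > 200000 nM, with no number behind it; this matches (the limit of > 200000 nM in this assay, at which 1 of the 3 values shown sits). Among the measured compounds shown here, no pair among the measured compounds differs in a single place, so no measured step is available.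

Compound 4 `C=CC#Cc1cn([C@H]2C[C@H](O)[C@@H](CO)O2)c(=O)[nH]c1=O` is the next entry. It differs from compound 2 as follows: a group of 4 heavy atoms (4 carbon; no ring) in place of a group of 6 heavy atoms (3 carbon, 1 nitrogen, 1 oxygen, 1 iodine; no ring), on an aromatic carbon. For the measured compounds named here, with no measured step to lean on, the expectation is that the step from compound 2 to compound 4 is downward and beyond the scatter, expected as a 5.4-fold lower number from compound 2 to compound 4 (0.73 log units; beyond the scatter) in this assay. For compound 4 the estimate in this assay is 20000 nM, expected to fall between 3000 nM and 150000 nM.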

Compound 4, half-maximal inhibitory concentration: > 200000 nM
Compound 4: only a limit was reported; the forecaster's own chance of this, stated with the estimate: 15%; at least 10-fold (1.00 log units) between middle value and limit.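

Compound 4 returns a limit and not a number in this assay: the limit of > 200000 nM in this assay, at which 2 of the 4 values shown sit.

Among the compounds shown here, this gives the only single-place step, an at least 1.8-fold higher number from compound 2 to compound 4 (0.27 log units; that floor lies within the scatter). At this aromatic carbon, then, replacing the (((iodomethyl)carbonyl)amino)methyl arm with the four-carbon group bearing one double and one triple bond gives no lower number, although the floor of the step does not by itself separate the two compounds beyond the scatter.

Going by these compounds, the true size of the step stays unknown, and this single pair cannot say which part of the arm in compound 2 matters, the iodine or the amide. On these data alone, whether an aminomethyl group, a carboxylic acid or a longer alkyl chain on this carbon would give a number rather than a limit also remains open.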